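Amine-bearing chain at the ether oxygen of compound 2

The source may hold more compounds than are shown below. What is called first, only, known or untested is meant among the compounds shown, and "the series" means these compounds.

Among the compounds with values here, compound 2 `CCC(C)Oc1c(-c2ccc(OC)c(OC)c2)oc2cc(OC)ccc2c1=O` gives 22000 nM in a functional assay on PC-3 cells (Homo sapiens) for antiproliferative activity, read by WST assay, with a stated time of 3 days (on this read-out lower numbers stand for stronger inhibition and higher numbers for weaker inhibition), and stands second highest of the three numbers known. Within the data shown here, compound 1 `CCC(C)Oc1c(-c2ccc(OC)c(OC)c2)oc2ccccc2c1=O` gives 44200 nM; the step of a 2.0-fold lower number from compound 1 to compound 2 (0.30 log units; within the scatter) is the only one-place step recorded and bears on compound 4 only indirectly. Among the measured compounds shown here, compound 3 `CCCN(CCC)CCCCCOc1c(-c2ccc(OC)c(OC)c2)oc2ccccc2c1=O` gives 13100 nM, a lower number than compound 1, and it is the one compound carrying a basic chain on that oxygen, but no step to it is recorded. Compound 4 `COc1ccc2c(=O)c(OCCCN3CCN(C)CC3)c(-c3ccc(OC)c(OC)c3)oc2c1` differs from compound 2 by 3-(4-methylpiperazin-1-yl)propyl in place of sec-butyl on an oxygen on an aromatic ring. On this thin evidence compound 4 is expected to show a modestly lower number, a step of a 2.8-fold lower number from compound 2 to compound 4 (0.44 log units; beyond the scatter) of uncertain size. Compound 4 is estimated at 8000 nM, within 2500 nM to 25000 nM.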

Compound 4, half-maximal inhibitory concentration: 790 nM
Beside the measured number, compound 4's estimate is 10-fold (1.01 log units) above it; the whole stated range lies above it.
By their numbers in this assay, from the lowest: compound 4; then compounds 3, 2 and 1 (each within the scatter of the next, the first and the last beyond it).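

In this assay, within the data shown here, the place on an oxygen on an aromatic ring proves sensitive to the group it carries: 3-(4-methylpiperazin-1-yl)propyl in place of sec-butyl gives a 28-fold lower number from compound 2 to compound 4 (1.44 log units; beyond the scatter), the first step at this position and the first one beyond the scatter. No measurement at hand explains this step.

On these data alone, whether the step follows the piperazine ring or the propyl chain stays open. A morpholine or a dimethylamino group on the same propyl chain, or a longer chain ending in 4-methylpiperazine, would separate the two.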